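Replacing the Amino Link with an Oxygen Link

This account rests on a few compounds, and the source may have more. Where it says the series, first, only, none or still open, it means among the compounds named here.

Of the compounds shown here, two with a shared core have been measured. Compound 1 `O=C(Nc1ccccc1Cl)N1CCN(c2nc(-c3ccc4ccccc4n3)no2)CC1` gives 140 nM in a functional assay on Shh Light II cells (Mus musculus) for inhibition, read by a luciferase reporter; on this read-out higher numbers stand for weaker inhibition and lower numbers for stronger inhibition. Compound 2 `Cc1ccccc1NC(=O)N1CCC(c2nc(-c3ccc4ccccc4n3)no2)CC1` gives 440 nM in this assay and so stands with the higher of the two numbers, that is, the weaker inhibition, and the gap between compound 1 and compound 2 lies beyond the usual scatter. These two compounds differ from each other in more than one place, so no single change can be read from that gap.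

Compound 3 `COc1ccccc1OC(=O)N1CCC(c2nc(-c3ccc4ccccc4n3)no2)CC1` has not yet been measured. It differs from compound 2 in one place: 2-methoxyphenoxy in place of (2-methylphenyl)amino on a carbonyl carbon. The leaving group carries the only hydrogen-bond donor of that part of the molecule, while the entering group brings two acceptors and no donor. Among the compounds with values here, no measured pair shows what such a change does on this core, so any expectation is uncertain. A modest shift toward weaker inhibition is expected, a step of a 2.0-fold higher number from compound 2 to compound 3 (0.31 log units; beyond the scatter) from one compound to the other. Compound 3 is estimated at 900 nM, with a likely range from 250 nM to 3500 nM.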

Compound 3, half-maximal inhibitory concentration: 250 nM
The estimate for compound 3 lay 3.6-fold (0.56 log units) above the measured number; low and high end bracket the measured number.
By their numbers in this assay, from the lowest: compounds 1, 3 and 2 (each within the scatter of the next, the first and the last beyond it).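

In this assay, putting 2-methoxyphenoxy in place of (2-methylphenyl)amino on the carbonyl carbon gives a 1.8-fold lower number from compound 2 to compound 3 (0.25 log units; within the scatter) and so the two compounds cannot be told apart on this read-out. The group that leaves carries a hydrogen-bond donor and the group that enters carries none, so this pair shows that, on this core, inhibition in this range can be kept without the amide hydrogen, something the earlier pair, which differed in more than one place, could not show. Nothing available offers an explanation for this outcome.

The step changes two things at once, the atom linking the aromatic ring to the carbonyl and the group on that ring, so their separate contributions cannot be read and they might offset each other. A 2-methylphenoxy or a (2-methoxyphenyl)amino group on the same carbonyl carbon would pull these two changes apart, while a cyclohexyloxy group would ask whether an aromatic ring is needed here at all.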